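This account rests on a few compounds, and the source may have more. Where it says the series, first, only, none or still open, it means among the compounds named here.

Measured so far:
Compound 1 `Cc1cccc(COc2ccc(-c3nn(CCC#N)c(=O)o3)cc2)c1` gives 8 nM in an assay for inhibition of Amine oxidase [flavin-containing] B (Rattus norvegicus); a higher number here means a weaker inhibitor, a lower number a stronger inhibitor.
Compound 2 `N#CCCCn1nc(-c2ccc(OCc3ccccc3)cc2)oc1=O` gives 410 nM in this assay.

Compound 2 stands at the higher of the two numbers, with compound 1 sitting far lower, beyond the scatter. Compound 3 `CC(C#N)Cn1nc(-c2ccc(OCc3ccccc3)cc2)oc1=O` keeps the core of compound 2 and differs only in the chain on the aromatic nitrogen: 1-cyanoethyl in place of 2-cyanoethyl on a saturated chain carbon bound to an aromatic nitrogen. Among the measured compounds shown here, no comparable step has been measured, so in this assay the step is expected to be small, likely a slight weakening, though it may stay within the scatter. Compound 3 is therefore estimated at 650 nM, between 150 nM and 2800 nM, an expected step of a 1.6-fold higher number from compound 2 to compound 3 (0.20 log units; within the scatter).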

Compound 3, half-maximal inhibitory concentration: 2400 nM
Beside the measured number, compound 3's estimate is 3.7-fold (0.57 log units) below it, and the stated range covers the measured number.
By their numbers in this assay, from the lowest: compound 1; then compound 2; then compound 3.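

In this assay, the change from 2-cyanoethyl to 1-cyanoethyl on a saturated chain carbon bound to an aromatic nitrogen gives a 5.9-fold higher number from compound 2 to compound 3 (0.77 log units; beyond the scatter), beyond the scatter. Since the two compounds hold the same atoms joined differently, this position responds to the arrangement of the chain and not only to its atoms. No available data bear on the reason for this weakening. Still open, from the compounds shown here alone, is whether an amine or a carboxylic acid in place of the nitrile would be tolerated here, and whether 1-cyanoethyl would cost as much on the core of compound 1.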